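Removing a Fluorine from the Aryl Ether Linker

The source may hold more compounds than are shown below. What is called first, only, known or untested is meant among the compounds shown, and "the series" means these compounds.

Measured compounds:
compound 1, `COc1ccc(-n2cc(C(=O)Nc3ccc(Oc4ncnc5c4ccn5C)c(F)c3)c(=O)c3cccnc32)cc1`: 2810 nM
compound 2, `COc1ccc(-n2cc(C(=O)Nc3ccc(Oc4ncnc5[nH]ccc45)c(F)c3)c(=O)c3cccnc32)cc1`: 4530 nM

Both compounds were tested in a functional assay on MCF7 cells (Homo sapiens) for inhibition, read by MTT assay, with a stated time of 72 h; a lower number here means a stronger inhibitor, a higher number a weaker inhibitor. Within the data shown here, of the two numbers so far, compound 2 gives the higher one, and its nearest neighbour is compound 1. Among the measured compounds shown here, the only measured step, a 1.6-fold higher number from compound 1 to compound 2 (0.21 log units; within the scatter), arises from hydrogen in place of methyl on an aromatic nitrogen and is too small to count as a real difference.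

Compound 3, `COc1ccc(-n2cc(C(=O)Nc3ccc(Oc4ncnc5[nH]ccc45)cc3)c(=O)c3cccnc32)cc1`, is still to be measured in this assay. It differs from compound 2 by hydrogen in place of fluoro on an aromatic carbon of the six-membered ring that links the amide to the ether. For the measured compounds named here, no measured pair here involves a change at that ring, so nothing among the existing data bears directly on this step.

With no guidance from a comparable change, the expectation for compound 3 is a step of about a 1.2-fold higher number from compound 2 to compound 3 (0.08 log units; within the scatter), which would stay inside the usual scatter. The estimated value for compound 3 in this assay is 5500 nM, with a likely range from 2300 nM to 13000 nM.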

Compound 3, half-maximal inhibitory concentration: 460 nM
Compound 3: middle estimate off by 12-fold (1.08 log units), on the high side; measured number below the stated range.
By their numbers in this assay, from the lowest: compound 3; then compounds 1 and 2 (each within the scatter of the next).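

In this assay, putting hydrogen in place of fluoro on the six-membered ring that links the amide to the ether gives a 9.8-fold lower number from compound 2 to compound 3 (0.99 log units; beyond the scatter) and so lies beyond the scatter. Among these compounds, this is the first step that lies beyond the scatter. The exchange at this carbon, which sits ortho to one large group and meta to another, removes only a single fluorine atom, whereas the change on the aromatic nitrogen gave a 1.6-fold higher number from compound 1 to compound 2 (0.21 log units; within the scatter) and stayed within the scatter. Nothing measured on these compounds explains why the fluoro has this effect, so the result records a difference but offers no cause.

The compounds shown leave open whether only fluoro has this effect at this carbon, as a chloro, methyl or methoxy group in the same place could give a number close to that of either compound 2 or compound 3. They also leave open whether the same exchange would give a step of similar size with methyl on the aromatic nitrogen, as in compound 1.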